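Removing a methoxymethyl group from a cytotoxic chalcone

The compounds below may be only part of what the source reports. "The series", "measured", "known", "first", "only" and "open" are said of these compounds alone.

The measured compounds are:
- compound 1, `COc1cc(OC)c(C(C)=O)c(OC)c1`, with 7200 nM in a functional assay on U-937 cells (Homo sapiens) for cytotoxicity, read by resazurin assay, with a stated time of 72 h; a higher number here means a weaker inhibitor, a lower number a stronger inhibitor
- compound 2, `COCOc1cc(OC)cc(OC)c1C(C)=O`, with 13300 nM in this assay
- compound 3, `COCOc1cc(OCOC)c(C(=O)/C=C/c2ccccc2)c(OCOC)c1`, with 8100 nM in this assay

Compound 1 and compound 2 differ in one place: hydrogen in place of methoxy on a saturated chain carbon bound to an oxygen on an aromatic ring. The step that goes with this change is a 1.8-fold lower number from compound 2 to compound 1 (0.27 log units; within the scatter), so the two numbers cannot be told apart with confidence.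

Compound 3 carries the same kind of side group as compound 2 but has a different core, and the difference between the two cores is not broken down here. Its value sits close to both of the others: compared with compound 1 and compound 2, the gaps are within the usual scatter, so no order among the three is claimed.

Compound 4, `COCOc1cc(OC)c(C(=O)/C=C/c2ccccc2)c(OCOC)c1`, has not yet been measured. It relates to compound 3 exactly as compound 1 relates to compound 2: hydrogen in place of methoxy on a saturated chain carbon bound to an oxygen on an aromatic ring. The two place lines agree word for word, so this is the same change made on a different core.

For the measured compounds named here, with only one measured example of this change, and that one within the scatter, the expected step is a small one: from compound 3 to compound 4 a step of about a 1.5-fold lower number from compound 3 to compound 4 (0.17 log units; within the scatter) is estimated, resting on the step from compound 2 to compound 1, a 1.8-fold lower number from compound 2 to compound 1 (0.27 log units; within the scatter). Compound 4 is therefore expected to give about 5500 nM, with a plausible range from 2500 nM to 12000 nM.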

Compound 4, half-maximal inhibitory concentration: 5900 nM
Compound 4: middle estimate off by 1.1-fold (0.03 log units), on the low side, and the stated range covers the measured number.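

In this assay, putting hydrogen in place of methoxy on a saturated chain carbon bound to an oxygen on an aromatic ring, which turns one methoxymethoxy into methoxy, gives a 1.4-fold lower number from compound 3 to compound 4 (0.14 log units; within the scatter). Set beside the earlier example of this change, on a different core, the two steps cannot be told apart: the same change on two cores in this assay, a 1.8-fold lower number (0.27 log units; within the scatter) from compound 2 to compound 1 and a 1.4-fold lower number (0.14 log units; within the scatter) from compound 3 to compound 4, 1.3-fold (0.13 log units) apart, within the scatter of two such steps. This shows that on both cores the change leaves the number within the usual scatter of repeated measurements, but it does not show that the change has any real effect on cytotoxicity, and two cores are too few to say how it would behave on a third.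

The compounds shown leave open whether a different group in this place, such as a longer chain like butoxy, an amine or a carboxylic acid, would give a step beyond the scatter, as they show only the swap from methoxymethoxy to methoxy. Also open, as far as these compounds go, is what would happen if the methoxymethoxy groups that remain on compound 4 were changed as well, and whether any of these results would hold outside this assay.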